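Ether side-chain swap on the aryl oxygen, compound 3

A few compounds are considered here, and "the series" means these few. Any claim that something is new, unique, unknown or untested is made for them only; others in the source may bear on it.

For the measured compounds named here, compound 2 `CC1(C)CCC(CN2CCN(c3ccc(C(=O)NS(=O)(=O)c4ccc(OC5CCOCC5)c([N+](=O)[O-])c4)c(Oc4cnc5[nH]ccc5c4)c3)CC2)=C(c2ccc(C(F)(F)F)cc2)C1` stands highest of the two numbers measured so far in an assay on isolated protein for displacement of a labelled ligand from Apoptosis regulator Bcl-2 (Homo sapiens), with a stated time of 15 min (on this read-out higher numbers stand for weaker inhibition and lower numbers for stronger inhibition), at 8.4 nM. Going by the values given here, compound 1 `CCN(CC)CCCNc1ccc(S(=O)(=O)NC(=O)c2ccc(N3CCN(CC4=C(c5ccc(C(F)(F)F)cc5)CC(C)(C)CC4)CC3)cc2Oc2cnc3[nH]ccc3c2)cc1[N+](=O)[O-]` gives 0.3 nM in this assay, and the only measured step in the set is a 28-fold higher number from compound 1 to compound 2 (1.45 log units; beyond the scatter), in which a chain carrying an amine gave way to the oxan-4-yl ring on the aromatic oxygen.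

Compound 3 `CCN1CCC(COc2ccc(S(=O)(=O)NC(=O)c3ccc(N4CCN(CC5=C(c6ccc(C(F)(F)F)cc6)CC(C)(C)CC5)CC4)cc3Oc3cnc4[nH]ccc4c3)cc2[N+](=O)[O-])CC1` is not yet measured. It differs from compound 2 by (1-ethylpiperidin-4-yl)methyl in place of oxan-4-yl on an oxygen on an aromatic ring. The step from compound 1 to compound 2 is the one that bears on this change: it was large, and compound 3 takes the oxan-4-yl ring out again and puts in a ring that contains a nitrogen and carries an ethyl, so it moves back toward the kind of substituent that compound 1 bears, although the attachment now runs through the oxygen rather than an amine. A partial reversal of the step from compound 1 to compound 2 is therefore expected, with the attachment change left as the open point.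

For compound 3 the expected step is a 7.0-fold lower number from compound 2 to compound 3 (0.85 log units; beyond the scatter). Compound 3 is therefore expected at 1.2 nM, with a range from 0.3 nM to 5 nM.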

Compound 3, half-maximal inhibitory concentration: 0.5 nM
Compound 3: middle estimate off by 2.4-fold (0.38 log units), on the high side; measured number inside the range.
By their numbers in this assay, from the lowest: compounds 1 and 3 (each within the scatter of the next); then compound 2.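

In this assay, (1-ethylpiperidin-4-yl)methyl in place of oxan-4-yl on the same oxygen gives a 17-fold lower number from compound 2 to compound 3 (1.23 log units; beyond the scatter), so the loss seen in a 28-fold higher number from compound 1 to compound 2 (1.45 log units; beyond the scatter) does not go with attachment through oxygen as such. Against the amine-linked side chain, the result is a 1.7-fold higher number from compound 1 to compound 3 (0.22 log units; within the scatter), so on this read-out (1-ethylpiperidin-4-yl)methoxy and (3-(diethylamino)propyl)amino cannot be told apart, although one is attached through oxygen and the other through an amine nitrogen. No measurement at hand accounts for the size of either step.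

The change from compound 2 to compound 3 alters the ring atom, the ethyl group and the methyl link together, so the compounds shown do not say which of these carries the step; (oxan-4-yl)methyl or 1-ethylpiperidin-4-yl on the same oxygen would separate them. Also open, going by these compounds, is how an unsubstituted piperidin-4-ylmethyl group or a (3-(diethylamino)propyl) chain would read on this oxygen, the latter giving a direct comparison of oxygen and amine attachment with the side chain held constant.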